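A Benzoxazolyl Group Replaces the Difluorophenyl Substituent

A few compounds are considered here, and "the series" means these few. Any claim that something is new, unique, unknown or untested is made for them only; others in the source may bear on it.

Compound 2 `O=C(O)CNC(=O)c1c(O)c2c(n(Cc3ccc(F)cc3F)c1=O)COC2` gives 2.2 nM in an assay on Sf9 cells for inhibition of prolyl hydroxylase EGLN2 (Homo sapiens), read by TR-FRET, with stated times of 30 min and 2 h (on this read-out higher numbers stand for weaker inhibition and lower numbers for stronger inhibition), and compound 1 `O=C(O)CNC(=O)c1c(O)c2c(n(Cc3ccc(OC(F)(F)F)cc3)c1=O)COC2` gives 2.4 nM in this assay, a pair that lies within the usual scatter, so neither can be set apart from the other. Compound 3 `O=C(O)CNC(=O)c1c(O)c2c(n(Cc3nc4ccccc4o3)c1=O)COC2` is the untested partner, and its change from compound 2 is 1,3-benzoxazol-2-yl in place of 2,4-difluorophenyl on a saturated chain carbon bound to an aromatic nitrogen. Among the measured compounds shown here, no comparable step between measured compounds exists here, so the expectation rests on the two benzyl analogues alone. For compound 3 the estimate in this assay is 4 nM, between 1.5 nM and 15 nM. The expected step of a 1.8-fold higher number from compound 2 to compound 3 (0.26 log units; within the scatter) is small, at the edge of the scatter.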

Compound 3, half-maximal inhibitory concentration: 5 nM
Beside the measured number, compound 3's estimate is 1.3-fold (0.10 log units) below it; low and high end bracket the measured number.
By their numbers in this assay, from the lowest: compounds 2 and 1 (each within the scatter of the next); then compound 3.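

In this assay, replacing 2,4-difluorophenyl with 1,3-benzoxazol-2-yl on a saturated chain carbon bound to an aromatic nitrogen gives a 2.3-fold higher number from compound 2 to compound 3 (0.36 log units; beyond the scatter), a modest loss. This place therefore tolerates a group with a five-membered aromatic ring with 2 hetero atoms, where compounds 1 and 2 carried only substituted phenyl rings. Nothing available bears on the reason for this step.

The compounds shown leave open whether a benzofuran-2-yl or a pyridin-2-yl group would behave like 1,3-benzoxazol-2-yl. They also leave open how an amine on the benzoxazole would change the number.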